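Removing the methylsulfonyl from an aryl sulfonamide

This account rests on a few compounds, and the source may have more. Where it says the series, first, only, none or still open, it means among the compounds named here.

Compound 1 `COC(=O)CC(CCc1ccc(C(=O)OC)cc1)c1cccc(C(=N)N)c1` is measured in an assay on isolated protein for inhibition of serine protease 1 (Homo sapiens) (a lower number here means a stronger inhibitor, a higher number a weaker inhibitor), at 330 nM, while compound 2 `COC(=O)CC(CCc1ccc(NS(C)(=O)=O)cc1)c1cccc(C(=N)N)c1` reaches 110 nM in this assay. Going by the values given here, the one step between them, a 3.0-fold lower number from compound 1 to compound 2 (0.48 log units; beyond the scatter), exchanges the ester for the sulfonamide at the same aromatic carbon. Among the two numbers so far, compound 2 holds the lower one, and the gap to compound 1 lies beyond the scatter.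

Compound 3 `COC(=O)CC(CCc1ccc(N)cc1)c1cccc(C(=N)N)c1` differs from compound 2 by hydrogen in place of methylsulfonyl on a nitrogen on an aromatic ring. Among the compounds with values here, no measured step bears directly on this change: the step from compound 1 to compound 2 introduces the whole methanesulfonamido group in place of methoxycarbonyl, whereas here the sulfonyl alone departs and the free amine remains. Within the data shown here, the only guidance is that the position tolerates some variation with modest effect, so a modest step is expected, more likely toward a higher number than a lower one, and possibly within the scatter. For compound 3 the estimate in this assay is 220 nM, with a range from 70 nM to 700 nM, which corresponds to an expected step of a 2.0-fold higher number from compound 2 to compound 3 (0.30 log units; within the scatter).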

Compound 3, inhibition constant: 1200 nM
Compound 3: the middle estimate sits 5.5-fold (0.74 log units) below what was measured; measured number above the stated range.
By their numbers in this assay, from the lowest: compound 2; then compound 1; then compound 3.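

In this assay, going by these compounds alone, the sulfonyl part of the methanesulfonamido group turns out to matter a great deal: taking away the methylsulfonyl and leaving the free amino gives an 11-fold higher number from compound 2 to compound 3 (1.04 log units; beyond the scatter), a large step, whereas the only earlier step at this aromatic carbon was modest. The amino group also falls short of the methoxycarbonyl it can be compared with, at a 3.6-fold higher number from compound 1 to compound 3 (0.56 log units; beyond the scatter), so this position is not indifferent to what it carries, and the three groups now rank methanesulfonamido, then methoxycarbonyl, then amino. The nitrogen alone therefore does not account for the standing of compound 2, since the difference between compound 2 and compound 3 lies entirely in the methylsulfonyl. Nothing available explains why the loss is this large.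

The compounds shown leave open whether a sulfonyl is needed on this nitrogen at all, or whether an acetyl group there would serve as well as the methylsulfonyl. They also leave open how an ethylsulfonyl or phenylsulfonyl group would compare, and whether a methyl on the sulfonamide nitrogen would change the number in this assay.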